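The source may report more compounds than this note shows. Statements on the series, on what has been measured and on what is new or still open speak of the compounds shown alone.

Notes on the series. Compound 1 `COc1ccc([C@@H]2OC[C@H]([C@@H](O)c3ccc(OC)c(OC)c3)C[C@H]2C/C=C/c2ccc(OC)c(OC)c2)cc1` gives 29200 nM in a functional assay on HeLa cells (Homo sapiens) for cytotoxicity, read by WST assay, with a stated time of 48 h; a higher number here means a weaker inhibitor, a lower number a stronger inhibitor. Compound 3 `COc1ccc(/C=C/C[C@@H]2C[C@@H]([C@@H](O)c3ccccc3)CO[C@H]2c2ccc(OC)c(OC)c2)cc1OC` gives 16800 nM in this assay, and compound 2 `COc1ccc(/C=C/C[C@H]2C[C@@H]([C@@H](O)c3ccccc3)CO[C@@H]2c2ccccc2)cc1` gives 8300 nM, the lowest number of the three; its gaps to compound 3 and to compound 1 both lie beyond the scatter. Compound 4 `O[C@@H](c1ccccc1)[C@H]1CO[C@H](c2ccccc2)[C@@H](C/C=C/c2ccncc2)C1` is not yet measured and differs from compound 2 in one place: pyridin-4-yl in place of 4-methoxyphenyl on a double-bonded chain carbon bound to a double-bonded chain carbon. The 4-methoxyphenyl of compound 2 leaves and pyridin-4-yl enters, one six-membered aromatic ring with 1 hetero atom in place of one six-membered aromatic ring of carbon only. Within the data shown here, no measured pair shows this change, so its size is uncertain; for compound 4 a modest move to a higher number in this assay is expected, possibly not beyond the scatter, a 1.4-fold higher number from compound 2 to compound 4 (0.16 log units; within the scatter). Compound 4 is estimated at 12000 nM in this assay, within a range of 4000 nM to 40000 nM.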

Compound 4, half-maximal inhibitory concentration: > 100000 nM
Compound 4: only a limit was reported (the forecaster's own chance of this, stated with the estimate: 5%); at least 8.3-fold (0.92 log units) between middle value and limit.
By their numbers in this assay, from the lowest: compound 2; then compounds 3 and 1 (each within the scatter of the next). At a limit, above all of these: compound 4.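

Among these compounds, the group on the double-bonded chain carbon matters in this assay, as the first single-place step shows: pyridin-4-yl in place of 4-methoxyphenyl gives an at least 12-fold higher number from compound 2 to compound 4 (1.08 log units; beyond the scatter). Compound 4 reads > 100000 nM, which is a limit of the assay and not a number. The true size of the step therefore stays unknown: the limit of > 100000 nM in this assay, at which 1 of the 4 values shown sits.

The compounds shown do not separate the departure of the methoxy group from the entry of the ring nitrogen. As far as these compounds go, how a plain phenyl or a pyridin-3-yl at this place would read in this assay remains open.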